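Chloro in Place of Fluoro on a Myeloperoxidase Inhibitor

The compounds below may be only part of what the source reports. "The series", "measured", "known", "first", "only" and "open" are said of these compounds alone.

Compound 1, `O=C(NO)c1ccc(Cc2ccccc2)cc1O`: 25 nM
Compound 2, `C[C@H]1CN(c2cc3c(cc2F)c(=O)c(C(=O)O)cn3C2CC2)CCN1`: > 5000 nM
Compound 3, `Cc1nc(N=C(N)N)nc2cc(F)ccc12`: 40 nM

Of the compounds shown here, three have been measured in an assay on isolated protein for inhibition of Myeloperoxidase (Homo sapiens), with a stated time of 5 min; on this read-out lower numbers stand for stronger inhibition and higher numbers for weaker inhibition. Compound 1 gives 25 nM and compound 3 gives 40 nM, two numbers that lie within the usual scatter of each other, so neither can be called the stronger. Compound 2 in this assay gives > 5000 nM, which is a limit of the assay rather than a number. Compound 4, `Cc1nc(N=C(N)N)nc2cc(Cl)ccc12`, has not yet been measured; it differs from compound 3 by chloro in place of fluoro on an aromatic carbon. Among the compounds with values here, no measured pair here shows a single change of this kind, so there is nothing to lean on. For such a swap a small step is expected, in either direction or none beyond the scatter. Compound 4 is therefore expected to give about 40 nM in this assay, within 15 nM to 120 nM, meaning an estimated step of no change at the digits printed from compound 3 to compound 4 (within the scatter).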

Compound 4, half-maximal inhibitory concentration: 96 nM
Compound 4: middle estimate off by 2.4-fold (0.38 log units), on the low side; the range from low to high includes it.
By their numbers in this assay, from the lowest: compounds 1 and 3 (each within the scatter of the next); then compound 4. At a limit, above all of these: compound 2.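

This aromatic carbon of the shared core is sensitive to which halogen it carries: in this assay, chloro in place of fluoro gives a 2.4-fold higher number from compound 3 to compound 4 (0.38 log units; beyond the scatter), a modest loss of inhibition from a swap of a single atom. Within the data shown here, it is the first single change in this set, so it gives the first direct reading of one position. Nothing measured here accounts for the direction of this step.

As far as these compounds go, whether hydrogen, bromo, methyl or an amine at this carbon would give a lower or higher number stays open. So does whether the same swap would act alike elsewhere on the shared core.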